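The source may report more compounds than this note shows. Statements on the series, on what has been measured and on what is new or still open speak of the compounds shown alone.

Within the data shown here, compound 3 `COc1ccc(-c2c(C#N)c(N)nc(SCc3csc(-c4ccc(F)cc4)n3)c2C#N)cc1` stands lowest of the three numbers so far in an assay on CHO cells for displacement of a labelled ligand from adenosine receptor A1 (Homo sapiens); a higher number here means a weaker inhibitor, a lower number a stronger inhibitor: compound 3 gives 2.3 nM. Compound 1 `COc1ccc(-c2c(C#N)c(N)nc(SCc3csc(-c4ccc(Cl)c(Cl)c4)n3)c2C#N)cc1` gives 11 nM, and compound 2 `COc1ccc(-c2c(C#N)c(N)nc(SCc3csc(-c4ccc(Cl)cn4)n3)c2C#N)cc1` gives 24 nM. The two steps that lead to compound 3, a 4.8-fold lower number from compound 1 to compound 3 (0.68 log units; beyond the scatter) and a 10-fold lower number from compound 2 to compound 3 (1.02 log units; beyond the scatter), both exchange the whole aromatic ring at that end of the molecule, and both moved the number beyond the scatter in the same direction, toward compound 3. Compound 4 `COc1ccc(-c2c(C#N)c(N)nc(SCc3csc(-c4ccc(I)cc4)n3)c2C#N)cc1` keeps that ring and differs from compound 3 only by iodo in place of fluoro on an aromatic carbon of a six-membered aromatic ring of carbon only, para to a large group. Among the measured compounds shown here, no measured step exchanges one halogen for another on the same ring, so the direct bearing of the measured steps is limited; they show only that the nature of this ring matters, with no case that goes the other way among compounds 1, 2 and 3. A modest step is therefore expected, with the direction open. For compound 4 the writer expects a number of 4 nM, between 1.2 nM and 14 nM, which means an expected step of a 1.7-fold higher number from compound 3 to compound 4 (0.24 log units; within the scatter).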

Compound 4, inhibition constant: 3.9 nM
Estimate against measurement, compound 4: 1.0-fold (0.01 log units) above; low and high end bracket the measured number.
By their numbers in this assay, from the lowest: compounds 3 and 4 (each within the scatter of the next); then compound 1; then compound 2.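

In this assay, among these compounds, the change from fluoro to iodo on the same ring gives a 1.7-fold higher number from compound 3 to compound 4 (0.23 log units; within the scatter) and so stays within the scatter, the first measured exchange of one halogen for another at this place. The 4-iodophenyl ring also keeps the separation from the other two rings, with a 2.8-fold lower number from compound 1 to compound 4 (0.45 log units; beyond the scatter) and a 6.2-fold lower number from compound 2 to compound 4 (0.79 log units; beyond the scatter), so among these four compounds the ring carrying a single halogen para to a large group stands apart from the 3,4-dichlorophenyl and 5-chloropyridin-2-yl rings, with no compound going against this. Nothing given here accounts for this result.

From the compounds shown here alone, whether this tolerance reaches beyond halogens remains open, as an amine, a carboxylic acid or a methoxy group at the same place could behave differently. The unsubstituted phenyl ring would show whether a group at this place matters at all.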